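Phenyl in place of piperidinylethyl on an acyltransferase inhibitor

The compounds below may be only part of what the source reports. "The series", "measured", "known", "first", "only" and "open" are said of these compounds alone.

Compound 1 `CCCCCCCCCCCCC(C)(C)C(=O)Nc1c(C)cc(C)c2c1OC(C)(C)C2` gives 33 nM in an assay for inhibition of acyl-CoA:cholesterol acyltransferase (Oryctolagus cuniculus), using microsomes; on this read-out lower numbers stand for stronger inhibition and higher numbers for weaker inhibition.
Compound 2 `Cc1cc(C)c(NC(=O)C(C)(C)CCCCCCN2CCCCC2)c2c1CC(C)(C)O2` gives only a limit of the assay, > 500 nM.

For the measured compounds named here, the one measured step, an at least 15-fold higher number from compound 1 to compound 2 (1.18 log units; beyond the scatter), shows that compound 2 sits at the limit of > 500 nM in this assay, at which 1 of the 2 values shown sits. Compound 3 `Cc1cc(C)c(NC(=O)C(C)(C)CCCCc2ccccc2)c2c1CC(C)(C)O2` differs from compound 2 by phenyl in place of 2-(piperidin-1-yl)ethyl on a saturated chain carbon, five bonds along the chain from a carbonyl carbon. This removes the piperidin-1-yl group whose arrival marked the large step of an at least 15-fold higher number from compound 1 to compound 2 (1.18 log units; beyond the scatter), but leaves a shorter chain than compound 1 carries. Compound 3 is therefore expected to improve on compound 2 by about an at least 3.3-fold lower number from compound 2 to compound 3 (0.52 log units; beyond the scatter). The estimate for compound 3 is 150 nM, ranging from 40 nM to 600 nM.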

Compound 3, half-maximal inhibitory concentration: 210 nM
Compound 3: the middle estimate sits 1.4-fold (0.15 log units) below what was measured, within the range that was stated.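

In this assay, phenyl in place of 2-(piperidin-1-yl)ethyl recovers some of the loss seen with the piperidine, giving an at least 2.3-fold lower number from compound 2 to compound 3 (0.37 log units; beyond the scatter). Compound 2 stands at a limit of the assay, so this step gives only a minimum size: the limit of > 500 nM in this assay, at which 1 of the 3 values shown sits. Phenyl still falls short of the all-carbon chain, with a 6.4-fold higher number from compound 1 to compound 3 (0.80 log units; beyond the scatter).

On these data alone, whether that gap belongs to the phenyl ring or to the shorter chain stays open, and a longer chain ending in phenyl would separate the two. As far as these compounds go, how a carboxylic acid in the same place would read is also open.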